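This account rests on a few compounds, and the source may have more. Where it says the series, first, only, none or still open, it means among the compounds named here.

Compound 1 `O=C1O/C(=C\Cn2cc(-c3cc(F)cc(F)c3)nn2)C(OCc2ccccc2)=C1OCc1ccccc1` in an ADME assay on HFF cells (Homo sapiens) for cytotoxicity, read by MTT assay, with a stated time of 72 h (on this read-out higher numbers stand for weaker inhibition and lower numbers for stronger inhibition), gives > 100000 nM, which is a limit of the assay rather than a number; it sits at the limit of > 100000 nM in this assay, at which 1 of the 3 values shown sits. Compound 2 `COc1ccc(-c2cn(C[C@H](O)[C@H]3OC(=O)C(OCc4ccccc4)=C3OCc3ccccc3)nn2)cc1` gives < 10 nM, again a limit, at the limit of < 10 nM in this assay, at which 1 of the 3 values shown sits. Compound 3 `COc1ccccc1-c1cn(C[C@H](O)[C@H]2OC(=O)C(OCc3ccccc3)=C2OCc2ccccc2)nn1` gives 50 nM. Among the measured compounds shown here, the one measured step, an at least 5.0-fold higher number from compound 2 to compound 3 (0.69 log units; beyond the scatter), shows that the aryl group on the five-membered aromatic ring with 3 nitrogen can move the read-out at least modestly. Compound 4 `O=C1O/C(=C\Cn2cc(-c3cccc(O)c3)nn2)C(OCc2ccccc2)=C1OCc1ccccc1` differs from compound 1 by 3-hydroxyphenyl in place of 3,5-difluorophenyl on an aromatic carbon. Compounds 2 and 3 carry a different core, so that step is only a loose guide, and with compound 1 at the upper limit no direction is fixed. Compound 4 is therefore expected near 80000 nM, within 10000 nM to 300000 nM, an expected at least 1.2-fold lower number from compound 1 to compound 4 (0.09 log units; that floor lies within the scatter), most likely reported again as a limit.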

Compound 4, half-maximal inhibitory concentration: 42600 nM
For compound 4 the middle estimate is 1.9-fold (0.27 log units) above the measured one; the measured number falls inside the stated range.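

On the core of compound 1, the aryl group on the five-membered aromatic ring with 3 nitrogen moves the read-out in this assay: 3-hydroxyphenyl in place of 3,5-difluorophenyl gives an at least 2.3-fold lower number from compound 1 to compound 4 (0.37 log units; beyond the scatter). This is the only step shown on this core, and it fixes a direction that the earlier pair, on a different core, could not. The value of compound 1 is a limit, so the size of the step is only a floor: the limit of > 100000 nM in this assay, at which 1 of the 4 values shown sits.

Still open, from the compounds shown here alone, is whether the hydroxy group or the loss of both fluorines carries the step. Also open, going by these compounds, is how an unsubstituted phenyl or a 3-aminophenyl group would read at this position.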